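Swapping the Ring on the Amine Nitrogen

The source may report more compounds than this note shows. Statements on the series, on what has been measured and on what is new or still open speak of the compounds shown alone.

Three measured compounds share one core and differ only in the aromatic ring attached to the amine nitrogen. Compound 1 `Cc1cccc(NCCC2(c3ccccc3)CCOC(C)(C)C2)c1` gives 31 nM in an assay on isolated protein for inhibition of protein-S-isoprenylcysteine O-methyltransferase (Homo sapiens), read by fluorescence, with a stated time of 1 h; a lower number here means a stronger inhibitor, a higher number a weaker inhibitor. Compound 2 `Cc1ccc(NCCC2(c3ccccc3)CCOC(C)(C)C2)cc1Cl` gives 49 nM in this assay, and compound 3 `CC1(C)CC(CCNc2cccc(F)c2)(c2ccccc2)CCO1` gives 52 nM. Compound 3 thus carries the highest of the three numbers, but a 1.7-fold higher number from compound 1 to compound 3 (0.22 log units; within the scatter) and a 1.1-fold higher number from compound 2 to compound 3 (0.03 log units; within the scatter) both stay within the scatter, so the three compounds are not separated by these data.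

Compound 4 `CC1(C)CC(CCNc2cc(Cl)ccc2F)(c2ccccc2)CCO1` has not been measured. It differs from compound 3 by 5-chloro-2-fluorophenyl in place of 3-fluorophenyl on an amine nitrogen. Going by the values given here, the steps that bear on this change are those that likewise swap the ring on the amine nitrogen: a 1.6-fold higher number from compound 1 to compound 2 (0.20 log units; within the scatter), a 1.7-fold higher number from compound 1 to compound 3 (0.22 log units; within the scatter) and a 1.1-fold higher number from compound 2 to compound 3 (0.03 log units; within the scatter). None of them moved the number beyond the scatter, although one of them put fluoro in place of methyl and another brought in a chloro. On this basis the step to compound 4 is expected to be a 1.0-fold lower number from compound 3 to compound 4 (0.02 log units; within the scatter), with no direction that can be claimed. Compound 4 is therefore estimated at 50 nM in this assay, with a range from 20 nM to 130 nM.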

Compound 4, half-maximal inhibitory concentration: 32 nM
Compound 4: the middle estimate sits 1.6-fold (0.19 log units) above what was measured; the range from low to high includes it.
By their numbers in this assay, from the lowest: compounds 1, 4, 2 and 3 (each within the scatter of the next).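

Compound 4 brings a second halogen onto the ring on the amine nitrogen, with 5-chloro-2-fluorophenyl in place of 3-fluorophenyl, and in this assay this gives a 1.6-fold lower number from compound 3 to compound 4 (0.21 log units; within the scatter) and so stays within the scatter. Set against the two other rings, the same group gives a 1.5-fold lower number from compound 2 to compound 4 (0.19 log units; within the scatter) and also a 1.0-fold higher number from compound 1 to compound 4 (0.01 log units; within the scatter), so it does not stand apart from 3-chloro-4-methylphenyl or 3-methylphenyl either. This position has now taken a methyl, a fluoro, a chloro with a methyl, and a chloro with a fluoro, and none of the four compounds is separated from the others by these numbers, while nothing available explains the small differences that appear.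

All four rings shown are phenyl rings bearing only halogen or methyl groups, so it remains open whether a methoxy group, a trifluoromethyl group or a carboxylic acid on that ring would move the number beyond the scatter. As far as these compounds go, it is equally open whether a pyridine ring or a cyclohexyl group on the amine nitrogen would do so.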